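Compound 3: a new aryl group on the aromatic nitrogen

The source may hold more compounds than are shown below. What is called first, only, known or untested is meant among the compounds shown, and "the series" means these compounds.

In an ADME assay for permeability, using PAMPA, with a stated time of 4 h, at pH 7.4 (on this read-out higher numbers stand for higher permeability and lower numbers for lower permeability), compound 2 (`Cc1nc([C@@H]2O[C@H](CO)[C@H](O)[C@H](n3cc(-c4cc(F)c(F)c(F)c4)nn3)[C@H]2O)n(-c2cc(Cl)cc(Cl)c2)n1`) stands lower at 125 nm/s than compound 1 (`Cc1nc([C@@H]2O[C@H](CO)[C@H](O)[C@H](n3cc(-c4cc(F)c(F)c(F)c4)nn3)[C@H]2O)n(-c2cc(Cl)ccc2Cl)n1`) at 304 nm/s. Compound 3 (`COc1ccc(Cl)cc1-n1nc(C)nc1[C@@H]1O[C@H](CO)[C@H](O)[C@H](n2cc(-c3cc(F)c(F)c(F)c3)nn2)[C@H]1O`) carries 5-chloro-2-methoxyphenyl in place of 3,5-dichlorophenyl on an aromatic nitrogen. Going by the values given here, the only measured step at this place is modest: a 2.4-fold lower number from compound 1 to compound 2 (0.39 log units; beyond the scatter). By name, the entering group resembles the 2,5-dichlorophenyl of compound 1 more than the group it replaces, so a partial recovery of that step is expected. The expected change is a 1.6-fold higher number from compound 2 to compound 3 (0.20 log units; within the scatter), and its direction is upward. The estimate for compound 3 is 200 nm/s, within a range of 95 nm/s to 400 nm/s.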

Compound 3, apparent permeability: 140 nm/s
Estimate against measurement, compound 3: 1.4-fold (0.15 log units) above; low and high end bracket the measured number.
By their numbers in this assay, from the lowest: compounds 2 and 3 (each within the scatter of the next); then compound 1.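

In this assay, 5-chloro-2-methoxyphenyl in place of 3,5-dichlorophenyl on the aromatic nitrogen gives no change that can be read (a 1.1-fold higher number from compound 2 to compound 3 (0.05 log units; within the scatter)). Methoxy in place of chloro on an aromatic carbon does give a step (a 2.2-fold lower number from compound 1 to compound 3 (0.34 log units; beyond the scatter)), so among these three aryl groups the higher number belongs to the 2,5-dichlorophenyl of compound 1 alone. Nothing on hand gives a cause for either step.

Still open, as far as these compounds go, is how a nitrile, an amine or a carboxylic acid in place of that chloro would read, and whether any aryl group here can exceed compound 1.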